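This account rests on a few compounds, and the source may have more. Where it says the series, first, only, none or still open, it means among the compounds named here.

Measured compounds in an assay on T-REx-293 cells for inhibition of potassium channel subfamily T member 1 (Homo sapiens), read by patch clamp; on this read-out higher numbers stand for weaker inhibition and lower numbers for stronger inhibition:
- compound 1, `Cc1cccc(-c2noc([C@H](C)NC(=O)c3cc(C4CC4)nn3C)n2)c1`: 167 nM
- compound 2, `C[C@H](NC(=O)c1cc(C2CC2)nn1C)c1nc(-c2ccccc2)no1`: 11400 nM
- compound 3, `Cc1ccnc(-c2noc([C@H](C)NC(=O)c3cc(C(F)(F)F)nn3C)n2)c1`: 4470 nM

Compound 3 stands second highest of the three numbers. Its nearest neighbour is compound 2, whose number is higher and beyond the scatter; its furthest is compound 1, whose number is far lower and also beyond the scatter. Going by the values given here, the one single-point step recorded in the set is a 68-fold higher number from compound 1 to compound 2 (1.83 log units; beyond the scatter), that is hydrogen in place of methyl on an aromatic carbon of the aryl group on the shared core. It shows that the aryl group attached to the core carries much of the variation seen in this assay.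

Compound 4, `COc1cc(-c2noc([C@H](C)NC(=O)c3cc(C(F)(F)F)nn3C)n2)cc(C)n1`, has not yet been measured. It differs from compound 3 as follows: 2-methoxy-6-methylpyridin-4-yl in place of 4-methylpyridin-2-yl on an aromatic carbon. Among the compounds with values here, no measured step exchanges one pyridyl group for another, so the step from compound 1 to compound 2 bears on it only indirectly, as a sign that substituents on this aryl ring move the number by a large amount. The direction is not fixed by the data; a step of modest size either way is expected, with wide uncertainty. Compound 4 is estimated at 2000 nM, range 300 nM to 15000 nM, which would be a step of a 2.2-fold lower number from compound 3 to compound 4 (0.35 log units; beyond the scatter).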

Compound 4, half-maximal inhibitory concentration: 505 nM
Beside the measured number, compound 4's estimate is 4.0-fold (0.60 log units) above it; the range from low to high includes it.
By their numbers in this assay, from the lowest: compound 1; then compound 4; then compound 3; then compound 2.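

In this assay, the aryl group on the aromatic carbon between two ring nitrogen atoms again moves the number, with an 8.9-fold lower number from compound 3 to compound 4 (0.95 log units; beyond the scatter), while trifluoromethyl stands where compound 1 and compound 2 carry cyclopropyl. The earlier step, a 68-fold higher number from compound 1 to compound 2 (1.83 log units; beyond the scatter), covered only methyl against hydrogen on the aryl ring, whereas this one shows that exchanging one pyridyl group for another also gives a step beyond the scatter, here towards stronger inhibition. The change replaces the whole ring substituent at once, and no measurement available here accounts for the lower number.

The compounds shown leave open how much of the step belongs to the methoxy group, the methyl group or the way the pyridine ring is attached, a question that 2-methoxypyridin-4-yl and 2-methylpyridin-4-yl groups would help to separate. Also open, as far as these compounds go, are whether an ethoxy or dimethylamino group could stand in place of methoxy, and whether 2-methoxy-6-methylpyridin-4-yl would behave the same way with cyclopropyl in place of trifluoromethyl.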